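The compounds below may be only part of what the source reports. "The series", "measured", "known", "first", "only" and "open" are said of these compounds alone.

Three compounds have so far been measured in an assay on isolated protein for inhibition of tissue alpha-L-fucosidase (Bos taurus), tested at 1000 uM; a higher number here means more inhibition at the concentration tested (going by the name of the read-out), a lower number less inhibition:

Compound 1 `COc1ccc([C@]2(CO)NC[C@@H](O)[C@@H]2O)cc1` gives 2.7%.
Compound 2 `CCCCCCCCC[C@]1(CO)NC[C@@H](O)[C@@H]1O` gives 0%.
Compound 3 `COc1ccc([C@@]2(CO)NC[C@H](O)[C@H]2O)cc1OC` gives 0.5%.

All three numbers are very small, and the gaps between them fall within the usual scatter of repeated measurements, so none of the three can be said to inhibit more or less than another. Compound 3 sits between the other two on the numbers shown, yet its distance to compound 2 and to compound 1 is in both cases smaller than the scatter, so it is not set apart from either.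

Compound 4 `COc1cccc([C@@]2(CO)NC[C@H](O)[C@H]2O)c1` has not yet been measured. It differs from compound 3 in one place: hydrogen in place of methoxy on an aromatic carbon. The shared core and the remaining methoxy group stay unchanged.

Among the measured compounds shown here, with three compounds all near zero inhibition and no measured step that bears on this change, a step of a number 1.5 percentage points higher from compound 3 to compound 4 (within the scatter) is expected, which is no more than the scatter. Compound 4 is therefore estimated to give 2%, with a likely range from 0% to 10%.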

Compound 4, a percentage reported as inhibition, at one concentration (the size of the read-out at that concentration, not a potency): 1.6%
The estimate for compound 4 lay 0.4 percentage points above the measured number; measured number inside the range.
By their numbers in this assay, from the lowest: compounds 2, 3, 4 and 1 (each within the scatter of the next).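

In this assay, among the compounds shown here, this is the first comparison of two compounds that differ in one place. Hydrogen in place of methoxy on this aromatic carbon, ortho to a methoxy group and para to a group of 9 heavy atoms, gives a number 1.1 percentage points higher from compound 3 to compound 4 (within the scatter). The two compounds therefore cannot be told apart, and this methoxy group makes no measurable difference to the read-out here. No supporting measurement is available to explain this result.

Going by these compounds, whether the remaining methoxy group matters stays open, as it is present in both compounds. It is also unknown whether an amine, a carboxylic acid or a longer chain on this aromatic carbon would produce a step beyond the scatter.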